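The compounds below may be only part of what the source reports. "The series", "measured", "known", "first", "only" and "open" are said of these compounds alone.

Working notes on the series. Compound 1 `COc1ccc(NC(=O)CSc2nnc(-c3cc(OC)c(OC)c(OC)c3)n2-c2ccc(OC)cc2)cc1`, compound 2 `COc1ccc(-n2c(SCC(=O)Nc3ccc(Cl)cc3)nnc2-c2cc(OC)c(OC)c(OC)c2)cc1` and compound 3 `COc1ccc(NC(=O)CSc2nnc(-c3cc(OC)c(OC)c(OC)c3)n2-c2ccc(N(C)C)cc2)cc1` were run in a functional assay on HCT-116 cells (Homo sapiens) for inhibition, read by MTT assay, with a stated time of 48 h; on this read-out higher numbers stand for weaker inhibition and lower numbers for stronger inhibition. In this assay compound 1 reaches only a limit, > 60000 nM. Compound 2 likewise gives only a limit, > 60000 nM. Compound 3 also stops at a limit, > 60000 nM. All three values sit at the limit of > 60000 nM in this assay, at which 3 of the 3 values shown sit, so neither a step that the two limits leave unreadable from compound 1 to compound 2 nor a step that the two limits leave unreadable from compound 1 to compound 3 can be read as a number. The change from compound 1 to compound 2 is chloro in place of methoxy on an aromatic carbon. The cores of compound 1 and compound 3 differ by dimethylamino in place of methoxy on an aromatic carbon. Compound 4 `COc1cc(-c2nnc(SCC(=O)Nc3ccc(Cl)cc3)n2-c2ccc(N(C)C)cc2)cc(OC)c1OC` is not yet measured in this assay. It differs from compound 3 by chloro in place of methoxy on an aromatic carbon, the same change as that from compound 1 to compound 2, at the same place. Because compound 1 and compound 2 both stop at the limit of > 60000 nM in this assay, at which 3 of the 3 values shown sit, the earlier step gives no readable size. The step expected in this assay is a step that the limit leaves unreadable from compound 3 to compound 4, resting on compound 3 standing at > 60000 nM and on the earlier change leaving no readable size. Compound 4 is expected near 100000 nM, between 40000 nM and 400000 nM, most likely reported as another limit.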

Compound 4, half-maximal inhibitory concentration: 39300 nM
The estimate for compound 4 lay 2.5-fold (0.41 log units) above the measured number; measured number outside the range, below it.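

In this assay, chloro in place of methoxy on the core of compound 3 gives an at least 1.5-fold lower number from compound 3 to compound 4 (0.18 log units; that floor lies within the scatter), and dimethylamino in place of methoxy on the core of compound 2 gives an at least 1.5-fold lower number from compound 2 to compound 4 (0.18 log units; that floor lies within the scatter). Compound 4 therefore carries a measured number where its two neighbours stop at limits, but both floors stay within the scatter, so neither change is shown to have a real effect, and the pairing of chloro with dimethylamino is not shown to exceed either change alone. The same chloro change on the core of compound 1 cannot be compared in size with the step to compound 4, and the dimethylamino step from compound 1 cannot be read either, because both ends of each stop at a limit: the limit of > 60000 nM in this assay, at which 3 of the 4 values shown sit.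

The compounds shown leave open whether a nitrile or a carboxylic acid in place of chloro on the 4-chlorophenyl group would give a readable number on the core of compound 4. They also leave open whether a primary amine in place of dimethylamino would keep that number.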